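A few compounds are considered here, and "the series" means these few. Any claim that something is new, unique, unknown or untested is made for them only; others in the source may bear on it.

The measured compounds in an assay on HEK293 cells for inhibition of Steryl-sulfatase (Homo sapiens), tested at 1 uM (on this read-out higher numbers stand for a stronger effect at the one concentration tested and lower numbers for a weaker effect), are compound 1 `CN(CCCN1CCCCC1)c1ccc(C(=O)N2CCc3ccc(OS(N)(=O)=O)cc3C2)cc1` at 40.7%, compound 2 `CCN(Cc1ccccn1)c1ccc(C(=O)N2CCc3ccc(OS(N)(=O)=O)cc3C2)cc1` at 87.7%, and compound 3 `CN(C)CCCN(Cc1ccccc1)c1ccc(C(=O)N2CCc3ccc(OS(N)(=O)=O)cc3C2)cc1` at 61.6%.

Compound 3 stands second of the three in this assay: compound 1 lies lower and compound 2 higher, both gaps beyond the scatter. Compound 4 `CCN(Cc1ccccc1)c1ccc(C(=O)N2CCc3ccc(OS(N)(=O)=O)cc3C2)cc1` differs from compound 3 in one place: hydrogen in place of (dimethylamino)methyl on a saturated chain carbon, two bonds along the chain from a nitrogen on an aromatic ring. Among the measured compounds shown here, no measured step matches this change exactly. For the measured compounds named here, the only step in hand is a number 47 percentage points higher from compound 1 to compound 2 (beyond the scatter), which likewise traded a longer chain on the aromatic nitrogen for a short alkyl, though its other substituent changed at the same time. On that basis compound 4 is expected to rise in this assay, a number 18.4 percentage points higher from compound 3 to compound 4 (beyond the scatter). Compound 4 is estimated at 80%, with a range from 60% to 95%.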

Compound 4, a percentage reported as inhibition, at one concentration (the size of the read-out at that concentration, not a potency): 83.6%
Beside the measured number, compound 4's estimate is 3.6 percentage points below it, within the range that was stated.
By their numbers in this assay, from the lowest: compound 1; then compound 3; then compounds 4 and 2 (each within the scatter of the next).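

Taking (dimethylamino)methyl off the saturated chain carbon and leaving hydrogen there gives a number 22 percentage points higher from compound 3 to compound 4 (beyond the scatter) in this assay and so isolates this chain change at the aromatic nitrogen. Phenyl in place of pyridin-2-yl gives a number 4.1 percentage points lower from compound 2 to compound 4 (within the scatter) and so does not separate the two rings. Benzyl(ethyl)amino in place of methyl(3-(piperidin-1-yl)propyl)amino gives a number 42.9 percentage points higher from compound 1 to compound 4 (beyond the scatter) and so shows a large rise with the pyridine nitrogen absent.

On these data alone, whether a carboxylic acid or a morpholine at the end of the chain would keep the higher number stays open. No measured evidence accounts for any of these steps.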